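This account rests on a few compounds, and the source may have more. Where it says the series, first, only, none or still open, it means among the compounds named here.

Measured so far in a functional assay for inhibition of sodium/hydrogen exchanger (Oryctolagus cuniculus); on this read-out higher numbers stand for weaker inhibition and lower numbers for stronger inhibition:
compound 1 `Cc1cc(O)c(S(C)(=O)=O)cc1C(=O)N=C(N)N` gives 220 nM
compound 2 `Cc1cc(Oc2cccc(Cl)c2)c(S(C)(=O)=O)cc1C(=O)N=C(N)N` gives 21 nM

Among the compounds with values here, compound 2 stands at the lowest number of the two; its nearest neighbour is compound 1, and the only step in the set, a 10-fold lower number from compound 1 to compound 2 (1.02 log units; beyond the scatter), separates them and lies beyond the scatter. Compound 3 `Cc1cc(N)c(S(C)(=O)=O)cc1C(=O)N=C(N)N` is not yet measured. amino in place of 3-chlorophenoxy on an aromatic carbon The 3-chlorophenyl that entered from compound 1 to compound 2 leaves again here, and amino enters at the same aromatic carbon, so compound 3 resembles compound 1 with amino where compound 1 carries hydrogen on an oxygen. Within the data shown here, the one measured step that bears on the change is the large one from compound 1 to compound 2; its reversal is the natural expectation, while nothing here tests amino against hydrogen on an oxygen. Because a 10-fold lower number from compound 1 to compound 2 (1.02 log units; beyond the scatter) was large, compound 3 is expected to take a step of a 12-fold higher number from compound 2 to compound 3 (1.08 log units; beyond the scatter) in this assay, back toward the number of compound 1. Going by these compounds, the estimate for compound 3 is 250 nM, with a range from 80 nM to 800 nM, kept wide since the amino change is untested.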

Compound 3, half-maximal inhibitory concentration: 16 nM
The estimate for compound 3 lay 16-fold (1.19 log units) above the measured number; the whole stated range lies above it.
By their numbers in this assay, from the lowest: compounds 3 and 2 (each within the scatter of the next); then compound 1.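

At this aromatic carbon, ortho to a methylsulfonyl group, the size of the substituent does not set the read-out in this assay: amino, with 1 heavy atom, replaces 3-chlorophenoxy, with 8 heavy atoms and an aromatic ring, in a 1.3-fold lower number from compound 2 to compound 3 (0.12 log units; within the scatter). The earlier large step, a 10-fold lower number from compound 1 to compound 2 (1.02 log units; beyond the scatter), therefore cannot be tied to the 3-chlorophenoxy ring, since a second large step, a 14-fold lower number from compound 1 to compound 3 (1.14 log units; beyond the scatter), comes from amino in place of hydroxy at the same carbon. Among the three groups shown, hydroxy is the one that stands apart, while amino and 3-chlorophenoxy lie within the scatter of each other on the shared core.

Going by these compounds, whether methoxy, dimethylamino or a plain hydrogen at this carbon would fall with hydroxy or with the other two remains open, and three compounds in a single assay cannot show which feature separates hydroxy from amino and 3-chlorophenoxy. No measurement in hand bears on why compound 1 stands apart from compound 2 and compound 3.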